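The source may report more compounds than this note shows. Statements on the series, on what has been measured and on what is new or still open speak of the compounds shown alone.

Measured compounds in this study:

Compound 1 `CC(Sc1nc2c(cnn2C)c(=O)n1-c1ccccc1)c1ccccn1` gives 89 nM in an assay on isolated protein for inhibition of Retinaldehyde dehydrogenase 3 (Homo sapiens); on this read-out higher numbers stand for weaker inhibition and lower numbers for stronger inhibition.
Compound 2 `C#Cc1ccc(-n2c(SC(C)c3ccccc3)nc3c(cnn3C)c2=O)cc1` gives 520 nM in this assay.
Compound 3 `CC(Sc1nc2c(cnn2C)c(=O)n1-c1ccc(CO)cc1)c1ccccc1` gives 1000 nM in this assay.

Compound 1 stands lowest of the three numbers in this assay; compound 2 lies nearest to it and compound 3 furthest, and both gaps reach beyond the scatter. Among the measured compounds shown here, the one step that can be read between single-point neighbours is a 1.9-fold higher number from compound 2 to compound 3 (0.28 log units; within the scatter), and it concerns the aryl group on the ring nitrogen, not the chain carbon.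

Compound 4 `CC(Sc1nc2c(cnn2C)c(=O)n1-c1ccccc1)c1cncnc1` has not yet been measured in this assay. It differs from compound 1 by pyrimidin-5-yl in place of pyridin-2-yl on a saturated chain carbon bound to a saturated chain carbon and a sulfur. For the measured compounds named here, no measured pair here changes the aryl on the chain carbon, so no step speaks to this change directly; compounds 2 and 3 carry a phenyl there but also differ at the ring nitrogen, and their values show only that they sit higher than compound 1. The expectation therefore rests on compound 1 alone and is wide. A moderate rise is expected, a 2.2-fold higher number from compound 1 to compound 4 (0.35 log units; beyond the scatter), a direction held loosely. Compound 4 is estimated at 200 nM, within 60 nM to 700 nM.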

Compound 4, half-maximal inhibitory concentration: 100 nM
The estimate for compound 4 lay 2.0-fold (0.30 log units) above the measured number, within the range that was stated.
By their numbers in this assay, from the lowest: compounds 1 and 4 (each within the scatter of the next); then compounds 2 and 3 (each within the scatter of the next).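

Putting pyrimidin-5-yl in place of pyridin-2-yl on a saturated chain carbon bound to a saturated chain carbon and a sulfur gives, in this assay, a 1.1-fold higher number from compound 1 to compound 4 (0.05 log units; within the scatter), so this pair cannot be told apart on this read-out. This is the first step shown at this position, and it shows that, with the rest of compound 1 held constant, one six-membered aromatic ring with 2 hetero atoms can stand in place of one with 1 hetero atom without the number moving beyond the scatter. No supporting measurement is available to explain this result.

The compounds shown leave open how a plain phenyl at this position would read with the unsubstituted phenyl kept on the ring nitrogen, since compound 2 and compound 3 differ from compound 1 at both places. They also leave open whether the position would accept an aromatic ring carrying an amine or a carboxylic acid, or a saturated ring such as piperidine in place of the aromatic ring.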